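The source may hold more compounds than are shown below. What is called first, only, known or untested is meant among the compounds shown, and "the series" means these compounds.

Compound 1 `O=C(O)CCc1ccc(NCc2ccc(Cl)cc2)cc1` is the reference point of this account. For the measured compounds named here, in a functional assay on CHO cells for agonist activity at Free fatty acid receptor 1 (Homo sapiens), read by reporter gene assay (a higher number here means a larger maximal response, a lower number a smaller maximal response), compound 1 gives 111%, the lowest of the three numbers so far in hand. Compound 2 `O=C(O)CCc1ccc(NCc2ccc(Cl)c(Cl)c2)cc1` carries an additional chloro on the same ring and gives 117% in this assay. Going by the values given here, compound 3 `O=C(O)CCc1ccc(NCc2ccc(Cl)s2)cc1`, in which the chlorinated six-membered ring is exchanged for a chlorinated thiophene, gives 143% in this assay, a number that stands clearly above that of compound 1, although no single-change step connects these two compounds.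

Compound 4 `Cc1ccc(CNc2ccc(CCC(=O)O)cc2)cc1` has not yet been measured. It differs from compound 1 in one place: methyl in place of chloro on an aromatic carbon. Among the compounds with values here, none of the measured steps exchanges a chloro for a methyl, so no direct precedent exists. Within the data shown here, the only measured single change, a number 6 percentage points higher from compound 1 to compound 2 (within the scatter), concerns a chloro entering on a ring carbon and stays within the scatter, which suggests that small changes at this ring leave the maximal response largely where it is. For compound 4 the expected step is a number 1 percentage points lower from compound 1 to compound 4 (within the scatter), which is not expected to go beyond the scatter. Compound 4 is therefore estimated at 110% in this assay, within a range of 92% to 130%.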

Compound 4, largest response reached (reported as percent of maximum), in percent of the reference or control that the assay uses: 152%
Estimate against measurement, compound 4: 42 percentage points below, outside the stated range (above it).
By their numbers in this assay, from the lowest: compounds 1 and 2 (each within the scatter of the next); then compounds 3 and 4 (each within the scatter of the next).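

In this assay, the step of a number 41 percentage points higher from compound 1 to compound 4 (beyond the scatter) shows that exchanging chloro for methyl on an aromatic carbon, para to a large group, can move the maximal response well beyond the scatter, even though one heavy atom leaves, one enters and the counted hydrogen-bond donors and acceptors stay the same. For the compounds shown here, the only earlier step, a number 6 percentage points higher from compound 1 to compound 2 (within the scatter), stayed within the scatter, so it gave no sign that this ring could respond so strongly, and the new step shows that a small change on it need not leave the maximal response where it is. Nothing available explains why methyl and chloro part so widely at this position.

Going by these compounds, whether the rise belongs to methyl alone, or would also appear with a hydrogen, an ethyl, a methoxy or a trifluoromethyl group at the same place, remains open. On these data alone, it is also open whether a methyl in place of the chloro on the thiophene of compound 3 would shift the maximal response in the same direction.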